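From 2-methoxyphenyl to 3-methoxyphenyl

The source may hold more compounds than are shown below. What is called first, only, known or untested is meant among the compounds shown, and "the series" means these compounds.

Compound 1 `CC(C)(C)C1=C(C(=O)O)N2C(=O)/C(=C/c3ccco3)C2O1` gives 0.22 h in a physicochemical assay for pharmacokinetics, read by fluorescence and HPLC, with a stated time of 24 h; a higher number here means that the compound lasts longer, a lower number that the compound disappears faster
Compound 2 `CC(C)(C)C1=C(C(=O)O)N2C(=O)/C(=C/c3ccoc3)C2O1` gives 0.32 h
Compound 3 `COc1ccccc1/C=C1/C(=O)N2C(C(=O)O)=C(C(C)(C)C)OC12` gives 0.2 h

All three values lie within the scatter of one another, so compound 3 stands level with the other two. Still unmeasured is compound 4 `COc1cccc(/C=C2/C(=O)N3C(C(=O)O)=C(C(C)(C)C)OC23)c1` with the change 3-methoxyphenyl in place of 2-methoxyphenyl on a double-bonded chain carbon bound to a double-bonded ring carbon and so 3-methoxyphenyl in place of 2-methoxyphenyl on a double-bonded chain carbon bound to a double-bonded ring carbon. Three measured steps at that place bear on it. They are a 1.5-fold higher number from compound 1 to compound 2 (0.16 log units; within the scatter) and a 1.1-fold lower number from compound 1 to compound 3 (0.04 log units; within the scatter) and also a 1.6-fold lower number from compound 2 to compound 3 (0.20 log units; within the scatter) and all stayed within the scatter. Going by the values given here, no compound with 3-methoxyphenyl has been measured yet. Those steps, with compound 3 at 0.2 h as the starting point, give no ground for a large move. The expected step is a 1.2-fold higher number from compound 3 to compound 4 (0.06 log units; within the scatter) with nothing beyond the scatter. For compound 4 the estimated value is 0.23 h within a range of 0.12 h to 0.42 h in this assay once it is measured.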

Compound 4, half-life: 0.21 h
Estimate against measurement, compound 4: 1.1-fold (0.04 log units) above; measured number inside the range.
By their numbers in this assay, from the lowest: compounds 3, 4, 1 and 2 (each within the scatter of the next).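

In this assay 3-methoxyphenyl in place of 2-methoxyphenyl gives a 1.1-fold higher number from compound 3 to compound 4 (0.02 log units; within the scatter) and so adds a change within one phenyl group to the earlier swaps of one ring for another at this place. Set against the two furans, the new group gives a 1.5-fold lower number from compound 2 to compound 4 (0.18 log units; within the scatter) and also a 1.0-fold lower number from compound 1 to compound 4 (0.02 log units; within the scatter) and so joins them, leaving all four groups within the scatter of one another. Nothing available explains this flat picture.

From the compounds shown here alone, whether an amine or a longer chain at this place would carry the half-life beyond the scatter stays open.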